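Swapping a ring substituent: from compound 1 to compound 4

A few compounds are considered here, and "the series" means these few. Any claim that something is new, unique, unknown or untested is made for them only; others in the source may bear on it.

Measured so far in a functional assay on NCI-H460 cells (Homo sapiens) for antiproliferative activity, read by CCK-8 assay, with a stated time of 72 h, tested at 2 uM; a higher number here means a stronger effect of the compound at the concentration tested, a lower number a weaker effect:
Compound 1 `Cc1ccc(Nc2nc(Cl)nc3c2ncn3Cc2ccc(C(=O)Nc3ccccc3N)cc2)cc1` gives 67.3%.
Compound 2 `Cc1ccc(Nc2nc(Cl)nc3c2ncn3Cc2ccc(/C=C/C(=O)Nc3ccccc3N)cc2)cc1` gives 31.3%.
Compound 3 `CCCCn1cnc2c(NCc3ccc(C(=O)Nc4ccccc4N)cc3)nc(Cl)nc21` gives 19.7%.

Compound 1 stands highest of these three, with compound 2 nearest and compound 3 furthest. Going by the values given here, the only step between compounds differing in one place, a number 36 percentage points lower from compound 1 to compound 2 (beyond the scatter), concerns a different part of the molecule. Compound 4 `Nc1ccccc1NC(=O)c1ccc(Cn2cnc3c(Nc4cccc(Cl)c4)nc(Cl)nc32)cc1` differs from compound 1 by 3-chlorophenyl in place of 4-methylphenyl on a nitrogen on an aromatic ring. Among the compounds with values here, no measured step touches this position; compound 3 differs from compound 1 in several places, so its lower value cannot be tied to any single change. With nothing directly comparable, the step is expected to stay within the scatter, leaning slightly lower: a number 9.3 percentage points lower from compound 1 to compound 4 (within the scatter). Compound 4 is therefore estimated at 58%, expected between 35% and 76%.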

Compound 4, a percentage reported as inhibition, at one concentration (the size of the read-out at that concentration, not a potency): 10.3%
The estimate for compound 4 lay 47.7 percentage points above the measured number, and the stated range ends above it.
By their numbers in this assay, from the lowest: compounds 4 and 3 (each within the scatter of the next); then compound 2; then compound 1.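

Going by these compounds alone, this position is far more sensitive than the earlier compounds could reveal. In this assay, 3-chlorophenyl in place of 4-methylphenyl on the nitrogen gives a number 57 percentage points lower from compound 1 to compound 4 (beyond the scatter) even though the heavy-atom, hydrogen-bond donor and hydrogen-bond acceptor counts of the group stay the same. Nothing measured here says why the number falls.

The swap changes both the substituent and its place on the ring, and the compounds shown do not separate the two. Either 4-chlorophenyl or 3-methylphenyl on the same nitrogen would tell them apart.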